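The source may hold more compounds than are shown below. What is called first, only, known or untested is meant among the compounds shown, and "the series" means these compounds.

Measured compounds in an assay on HEK293 cells for inhibition of Voltage-dependent T-type calcium channel subunit alpha-1G (Homo sapiens), read by fluorescence, tested at 10 uM; a higher number here means more inhibition at the concentration tested (going by the name of the read-out), a lower number less inhibition:

Compound 1 `CCCc1nc(-c2ccccc2)c(CNCCN2CCN(c3cccc(C(F)(F)F)c3)CC2)o1` gives 56.3%.
Compound 2 `CCCc1nc(-c2ccccc2)c(CNCCCN2CCN(c3ccc(C)cc3)CC2)o1` gives 53.9%.
Compound 3 `CCCc1nc(-c2ccccc2)c(CNCCCN2CCN(c3cccc(F)c3)CC2)o1` gives 68.9%.

Compound 1 stands second highest of the three numbers. Its nearest neighbour is compound 2, whose value lies within the scatter of compound 1, so no order between them can be read. Compound 3 sits beyond the scatter above compound 1, but the two differ in more than one place, so only their values can be compared.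

The unmeasured compound 4 `CCCc1nc(-c2ccccc2)c(CNCCN2CCN(c3cccc(F)c3)CC2)o1` arises from compound 1 by the change (fluoro in place of trifluoromethyl on an aromatic carbon). Among the compounds with values here, only one measured step bears on it, and indirectly: a number 15 percentage points higher from compound 2 to compound 3 (beyond the scatter), which installs the same 3-fluorophenyl but removes 4-methylphenyl rather than trifluoromethyl, and on the longer linker. Nothing measured removes trifluoromethyl directly. The values of compound 1 and compound 3 both lie in the middle range, which suggests the change will be modest at most.

Compound 4 is therefore expected to move by a number 4.7 percentage points higher from compound 1 to compound 4 (within the scatter) from compound 1, giving an estimate of 61% with a range from 46% to 76%.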

Compound 4, a percentage reported as inhibition, at one concentration (the size of the read-out at that concentration, not a potency): 62.3%
For compound 4 the middle estimate is 1.3 percentage points below the measured one; low and high end bracket the measured number.
By their numbers in this assay, from the lowest: compounds 2, 1, 4 and 3 (each within the scatter of the next, the first and the last beyond it).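

In this assay, within the data shown here, the direct swap of fluoro for trifluoromethyl on this aromatic carbon comes out as a number 6 percentage points higher from compound 1 to compound 4 (within the scatter), the first reading of this change, since the earlier step reached 3-fluorophenyl only from 4-methylphenyl. At this position, then, a group of 4 heavy atoms gives way to one of 1 heavy atom with no difference that can be read beyond the scatter. No measurement shown here offers a reason for this outcome.

Still open, going by these compounds, is how a group such as chloro, methoxy or nitrile, or plain hydrogen, would read on this aromatic carbon. Also open, on these data alone, is whether trifluoromethyl and fluoro would read alike on the longer linker carried by compound 3.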